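The source may hold more compounds than are shown below. What is called first, only, known or untested is meant among the compounds shown, and "the series" means these compounds.

Compound 2, `Cc1ccc(NC(=O)Nc2cc(C)nc3ccccc23)cc1`, is one of the two compounds whose result in an ADME assay on HEK293 cells (Homo sapiens) for cytotoxicity, with a stated time of 72 h (a lower number here means that less compound is needed, a higher number that more compound is needed for the effect), is a limit of the assay rather than a number: in this assay compound 2 gives > 25000 nM. Compound 1, `Cc1cc(NC(=O)Nc2ccc(C)c(Cl)c2)c2ccccc2n1`, likewise gives only the limit > 25000 nM in this assay. For the measured compounds named here, compound 3, `Cc1cc(NC(=O)Nc2cccc(Cl)c2)c2ccccc2n1`, is the single compound with a number in this assay, at 21000 nM. The measured steps are a step that the two limits leave unreadable from compound 1 to compound 2, an at least 1.1-fold lower number from compound 1 to compound 3 (0.07 log units; that floor lies within the scatter) and an at least 1.1-fold lower number from compound 2 to compound 3 (0.07 log units; that floor lies within the scatter); the last two reach only a floor that lies within the scatter, and the limit of > 25000 nM in this assay, at which 2 of the 3 values shown sit, makes the first unreadable.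

Compound 4, `Cc1cc(NC(=O)Nc2ccc(SC(F)(F)F)cc2)c2ccccc2n1`, differs from compound 2 by (trifluoromethyl)sulfanyl in place of methyl on an aromatic carbon. Going by the values given here, the only measured step at the same amide-type nitrogen is the one from compound 2 to compound 3, which exchanges the whole aryl group and still stays within the scatter. Among the compounds with values here, no measured step introduces (trifluoromethyl)sulfanyl. The expectation for compound 4 in this assay is therefore a step of a number no higher from compound 2 to compound 4 (the limit leaves the size open), that is, none beyond the scatter, with a good chance that the assay again reports only a limit. Compound 4 is estimated at 25000 nM, between 12000 nM and 60000 nM.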

Compound 4, half-maximal effective concentration: 13000 nM
Compound 4: the middle estimate sits 1.9-fold (0.28 log units) above what was measured; measured number inside the range.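

Placing (trifluoromethyl)sulfanyl on this aromatic carbon, para to a large group, gives the first change at this position that can be read at all, as an at least 1.9-fold lower number from compound 2 to compound 4 (0.28 log units; that floor lies within the scatter). Unlike the methyl of compound 2, this group comes with a number rather than a limit in this assay, yet what can be read remains a floor within the scatter, so the change is not shown to shift the number beyond it. How large the step really is cannot be said, as the reading from compound 2 rests on a limit of the assay: the limit of > 25000 nM in this assay, at which 2 of the 4 values shown sit.

From the compounds shown here alone, what a methoxy group, an amine or a carboxylic acid on this same aromatic carbon would give in this assay stays open, as does whether any group here can move the number beyond the scatter from compound 2. Also open, going by these compounds, is how far compound 4 truly lies from compound 2, which only a number for compound 2 in place of its limit could settle.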